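Taking one methyl off the piperidine of compound 2

The compounds below may be only part of what the source reports. "The series", "measured", "known", "first", "only" and "open" are said of these compounds alone.

Values so far in a physicochemical assay for lipophilicity, measured as octanol-water partition, at pH 7.4 (on this read-out higher numbers stand for higher lipophilicity and lower numbers for lower lipophilicity), are these:
- compound 1 `Cc1ccc2[nH]c(C(=O)N[C@H]3CN(S(=O)(=O)c4ccccc4)C[C@@H]3C(=O)NCCN(C)C)cc2c1` gives 2.1 here
- compound 2 `Cc1ccc2[nH]c(C(=O)N[C@H]3CN(S(=O)(=O)c4ccccc4)C[C@@H]3C(=O)N[C@H]3CCCN(C)C3)cc2c1` gives 2.7 here

Compound 2 holds the higher of the two numbers, and its gap to compound 1 is larger than the usual scatter of repeat measurements. The next compound, compound 3 `Cc1ccc2[nH]c(C(=O)N[C@H]3CN(S(=O)(=O)c4ccccc4)C[C@@H]3C(=O)N[C@@H]3CCCNC3)cc2c1`, keeps the shared core and differs from compound 2 in one place (piperidin-3-yl in place of 1-methylpiperidin-3-yl on an amide-type nitrogen). In plain terms, piperidin-3-yl stands in place of 1-methylpiperidin-3-yl on an amide-type nitrogen.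

Among the measured compounds shown here, only one measured step can serve as a guide, and it is an imperfect one. It is a number 0.60 log units higher from compound 1 to compound 2 (beyond the scatter), and it swaps a different pair of groups. For the measured compounds named here, no measured step removes a methyl group alone, so that step offers a rough size and no direct precedent. Its direction was upward, whereas the downward direction expected here is a judgement from the counted change, untested by these data. The estimated step is a number 0.50 log units lower from compound 2 to compound 3 (beyond the scatter), a modest one. For compound 3 the estimated value in this assay is 2.2 (expected range 1.8 to 2.6).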

Compound 3, distribution coefficient: 1.3
Estimate against measurement, compound 3: 0.90 log units above; measured number below the stated range.
By their numbers in this assay, from the lowest: compound 3; then compound 1; then compound 2.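

In this assay, the swap of 1-methylpiperidin-3-yl for piperidin-3-yl on the amide-type nitrogen gives a number 1.40 log units lower from compound 2 to compound 3 (beyond the scatter), a large step and clearly bigger than the earlier a number 0.60 log units higher from compound 1 to compound 2 (beyond the scatter), so this position responds strongly even to a change this small on paper. The entering group carries 1 hydrogen-bond donor where the leaving group carries 0, and the result also puts the 2-(dimethylamino)ethyl compound in the middle of the three, with a number 0.80 log units lower from compound 1 to compound 3 (beyond the scatter), so the two piperidine-bearing compounds fall on opposite sides of it. Nothing measured here explains why the step is so large.

The defined stereocentre of the piperidine ring is drawn with opposite handedness in compound 2 and compound 3, so these two compounds alone cannot separate the loss of the methyl from that change in handedness. From the compounds shown here alone, how the number would move with a longer chain on the ring nitrogen, such as 1-ethylpiperidin-3-yl, or with an acetyl group there, also stays open.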